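The source may report more compounds than this note shows. Statements on the series, on what has been measured and on what is new or still open speak of the compounds shown alone.

Measured in a functional assay on PC-3 cells (Homo sapiens) for cytotoxicity, read by MTT assay, with a stated time of 72 h; on this read-out higher numbers stand for weaker inhibition and lower numbers for stronger inhibition:
Compound 1 `O=C(N/N=C/c1ccc(F)cc1)Nc1cc2c(Nc3ccc(F)c(Cl)c3)ncnc2cc1O[C@H]1CCOC1`: "not active" (no number reported)
Compound 2 `O=C(N/N=C/c1ccc(F)cc1Cl)Nc1cc2c(Nc3ccc(F)c(Cl)c3)ncnc2cc1O[C@H]1CCOC1`: 28400 nM
Compound 3 `COc1cc2ncnc(Nc3ccc(F)c(Cl)c3)c2cc1NC(=O)N/N=C/c1ccc(F)cc1Cl`: 25700 nM

Only compound 2 and compound 3 give numbers in this assay, and these two lie within the scatter of each other, while compound 1 gives none. Within the data shown here, compound 3 therefore stands level with its only numerical neighbour. Compound 4 `COc1cc2ncnc(Nc3ccc(F)c(Cl)c3)c2cc1NC(=O)N/N=C/c1ccc(O)cc1O` keeps the rest of compound 3 and alters the group on the carbon with a double bond to nitrogen: 2,4-dihydroxyphenyl in place of 2-chloro-4-fluorophenyl on a carbon with a double bond to nitrogen.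

Among the measured compounds shown here, the one measured step, a 1.1-fold lower number from compound 2 to compound 3 (0.04 log units; within the scatter), concerns the group on an oxygen on an aromatic ring, so it does not test this change. The aromatic group on that same carbon also differs between compound 1 and compound 2. Compound 1 is reported as "not active" (no number reported). Compound 2 gives 28400 nM. That pair yields no step size, but it leaves open that a change at this place could cost the number altogether. No step beyond the scatter can be predicted in either direction, and the expected result in this assay is a wide one. The expected change is a 1.1-fold lower number from compound 3 to compound 4 (0.03 log units; within the scatter). For compound 4 the estimated value is 24000 nM, with an expected range from 8000 nM to 70000 nM.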

Compound 4, half-maximal inhibitory concentration: 29500 nM
Compound 4: middle estimate off by 1.2-fold (0.09 log units), on the low side; low and high end bracket the measured number.
By their numbers in this assay, from the lowest: compounds 3, 2 and 4 (each within the scatter of the next).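

In this assay, 2,4-dihydroxyphenyl in place of 2-chloro-4-fluorophenyl on the carbon with a double bond to nitrogen gives a 1.1-fold higher number from compound 3 to compound 4 (0.06 log units; within the scatter). Among these compounds, this is the first step that can be read at this position, and it shows that an exchange of a ring with 0 hydrogen-bond donors for one with 2, at the same count of 8 heavy atoms, leaves compound 4 within the scatter of compound 3, so the chlorine and fluorine on this ring are not required for compound 4 to give a number. The compounds shown offer no measurement that accounts for this result.

On these data alone, it remains open whether any group at this place can move the number beyond the scatter, for instance a ring bearing an amine or a carboxylic acid, a pyridine ring, or a saturated cyclohexyl ring. As far as these compounds go, it is also open whether 2,4-dihydroxyphenyl would behave in the same way with oxolan-3-yl in place of methyl on the oxygen on the aromatic ring, where the chlorine- and fluorine-bearing ring gave the step of a 1.1-fold lower number from compound 2 to compound 3 (0.04 log units; within the scatter).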